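Working notes: replacing the 2-nitrophenyl group of compound 3

This account rests on a few compounds, and the source may have more. Where it says the series, first, only, none or still open, it means among the compounds named here.

- compound 1 `O=C(/C=C/c1ccccc1)NNC(=O)c1ccc2c(c1)OCCO2`: 550 nM
- compound 2 `Cc1cccc(/C=C/C(=O)NNC(=O)c2ccc3c(c2)OCCO3)c1`: 2890 nM
- compound 3 `O=C(/C=C/c1ccccc1[N+](=O)[O-])NNC(=O)c1ccc2c(c1)OCCO2`: 890 nM

All three values come from a functional assay on cells (Cancer cell lines, Homo sapiens) for inhibition, read by MTT assay, with a stated time of 48 h; on this read-out lower numbers stand for stronger inhibition and higher numbers for weaker inhibition. Among them, compound 3 at 890 nM lies close to one neighbour and far from the other. The data show a 1.6-fold higher number from compound 1 to compound 3 (0.21 log units; within the scatter), and also a 3.2-fold lower number from compound 2 to compound 3 (0.51 log units; beyond the scatter).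

The unmeasured compound 4 `O=C(/C=C/c1cccc(F)c1)NNC(=O)c1ccc2c(c1)OCCO2` differs from compound 3 as follows: 3-fluorophenyl in place of 2-nitrophenyl on a double-bonded chain carbon bound to a double-bonded chain carbon. Among the measured compounds shown here, no fluorine-bearing compound has been measured in this small set, so any expectation rests on indirect evidence. For the measured compounds named here, the only measured compound with a group named at the 3 position of the phenyl is compound 2, and it gives a modest penalty: a 5.3-fold higher number from compound 1 to compound 2 (0.72 log units; beyond the scatter). Going by the values given here, the nitro change gives no step that can be told from noise: a 1.6-fold higher number from compound 1 to compound 3 (0.21 log units; within the scatter). Compound 4 could therefore fall near compound 3 or drift towards compound 2, and three compounds cannot settle which. With evidence this thin, no clear shift is expected in this assay, though a weak lean towards a higher number remains possible. The expected result is a 1.2-fold higher number from compound 3 to compound 4 (0.09 log units; within the scatter), which is none beyond the scatter. For compound 4 the estimate is 1100 nM, with an expected range from 400 nM to 3000 nM.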

Compound 4, half-maximal inhibitory concentration: 4110 nM
The estimate for compound 4 lay 3.7-fold (0.57 log units) below the measured number; the whole stated range lies below it.
By their numbers in this assay, from the lowest: compounds 1 and 3 (each within the scatter of the next); then compounds 2 and 4 (each within the scatter of the next).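

In this assay, the 3-fluorophenyl group does not keep the level seen with the 2-nitrophenyl group, and the change gives a 4.6-fold higher number from compound 3 to compound 4 (0.66 log units; beyond the scatter). Against the unsubstituted phenyl of the series, the fluoro group gives a 7.5-fold higher number from compound 1 to compound 4 (0.87 log units; beyond the scatter), a clear penalty where the nitro group gave no step that could be told from the scatter. Fluoro in place of methyl gives a 1.4-fold higher number from compound 2 to compound 4 (0.15 log units; within the scatter), which lies within the scatter, so the two compounds carrying a 3-substituted phenyl group stand together on the weaker side of compounds 1 and 3, although no independent evidence bears on why the steps arise.

Among the compounds shown here, with only two such compounds, it remains open whether the penalty goes with the 3 position of the phenyl group in general or only with methyl and fluoro there. A 3-aminophenyl or 3-methoxyphenyl group could test the first reading, and a 2-fluorophenyl group would show whether fluoro keeps its penalty when the ring carries it where compound 3 carries its nitro group.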